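The source may report more compounds than this note shows. Statements on the series, on what has been measured and on what is new or still open speak of the compounds shown alone.

The three measured compounds share one core carrying a phenyl-type ring on one side and an amine-linked saturated ring on the other. Going by the values given here, in an assay on CHO cells for displacement of a labelled ligand from adenosine receptor A3 (Homo sapiens), read by scintillation counting, with a stated time of 3 h (a lower number here means a stronger inhibitor, a higher number a weaker inhibitor), compound 3 `Cc1cccc(-c2nc3c(NC4CCCC4)ncnc3n2C)c1` gives 510 nM, the lowest of the three numbers measured so far. Among the compounds with values here, its nearest neighbour is compound 1 `Cn1c(-c2ccc(F)cc2)nc2c(NC3CCCC3)ncnc21`, which in this assay gives 1140 nM; that comparison is the only single-change step available, and it reads a 2.2-fold lower number from compound 1 to compound 3 (0.35 log units; beyond the scatter). Furthest away stands compound 2 `Cn1c(-c2ccccc2)nc2c(NC3CCOC3)ncnc21`, which in this assay gives 6260 nM; compound 2 differs from compound 3 in two places, so its number shows only the overall gap and nothing about either change alone.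

Compound 4 `Cn1c(-c2ccccc2)nc2c(NC3CCCC3)ncnc21` has not yet been measured. It differs from compound 3 by hydrogen in place of methyl on an aromatic carbon. Within the data shown here, the only step that bears on this change is the one from compound 1 to compound 3, which was modest and went toward a lower number when the 3-methylphenyl group arrived. Removing the methyl again, to leave a plain phenyl, is therefore expected to move the number back upward in this assay by a modest amount, a 1.8-fold higher number from compound 3 to compound 4 (0.25 log units; within the scatter), rather than leaving it within the scatter. Compound 4 is accordingly estimated at 900 nM, with a plausible range from 400 nM to 2200 nM.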

Compound 4, inhibition constant: 846 nM
The estimate for compound 4 lay 1.1-fold (0.03 log units) above the measured number; the measured number falls inside the stated range.
By their numbers in this assay, from the lowest: compounds 3, 4 and 1 (each within the scatter of the next, the first and the last beyond it); then compound 2.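

In this assay the plain phenyl of compound 4 splits the earlier aryl comparison into two parts: a 1.7-fold higher number from compound 3 to compound 4 (0.22 log units; within the scatter) for losing the methyl, and a 1.3-fold lower number from compound 1 to compound 4 (0.13 log units; within the scatter) for losing the fluoro. Both parts lie within the scatter, so neither substituent, taken against hydrogen alone, is shown to shift the number on this aromatic ring, although the 3-methylphenyl and 4-fluorophenyl compounds do stand apart from each other. Going by these compounds alone, compound 4 also gives the first single-change reading of the ring on the amine nitrogen, where cyclopentyl replaces oxolan-3-yl: a 7.4-fold lower number from compound 2 to compound 4 (0.87 log units; beyond the scatter) is the only one of these new steps beyond the scatter, and the overall gap seen earlier between compounds 2 and 3 could not show this. Nothing available explains either the small aryl steps or the larger ring step.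

The compounds shown leave open whether a methoxy group or a chlorine on the phenyl ring would move the number beyond the scatter. They also leave open how a cyclohexyl ring or an open butyl chain on the amine nitrogen would compare with cyclopentyl.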